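Trifluoromethyl for fluoro: the step to compound 4

The compounds below may be only part of what the source reports. "The series", "measured", "known", "first", "only" and "open" are said of these compounds alone.

Compound 1 `CN1C/C(=C\c2cccnc2)C(=O)/C(=C/c2ccccc2C(F)(F)F)C1`: 2910 nM
Compound 2 `O=C1/C(=C/c2cccnc2)CNC/C1=C\c1ccccc1F`: 8890 nM
Compound 3 `O=C1/C(=C/c2cccnc2)CN(S(=O)(=O)c2ccc(Cl)cc2)C/C1=C\c1ccccc1F`: 12100 nM

These three compounds were measured in a functional assay on QGY-7703 cells (Homo sapiens) for cytotoxicity, read by MTT assay, with a stated time of 24 h; on this read-out lower numbers stand for stronger inhibition and higher numbers for weaker inhibition. Compound 2, at 8890 nM, lies within the scatter of compound 3, whereas compound 1 shows a lower number, beyond the scatter. Compound 4 `O=C1/C(=C/c2cccnc2)CNC/C1=C\c1ccccc1C(F)(F)F` has not yet been measured. It departs from compound 2 by a single change: trifluoromethyl in place of fluoro on an aromatic carbon.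

Within the data shown here, only one measured step bears on this indirectly. That step, a 1.4-fold higher number from compound 2 to compound 3 (0.13 log units; within the scatter), concerns the amine nitrogen in a ring and stays within the scatter, so a large change at that nitrogen left the number in this assay unmoved here. Among the measured compounds shown here, no measured pair isolates the exchange of fluoro for trifluoromethyl. The closest evidence is compound 1 at 2910 nM, which carries trifluoromethyl and a methyl on that nitrogen. This suggests a moderate fall in the number rather than none, though one compound is thin support.

The expected change is a 2.1-fold lower number from compound 2 to compound 4 (0.33 log units; beyond the scatter), which remains an estimate. For compound 4 the estimated value is 4200 nM, with an expected range from 1700 nM to 10000 nM.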

Compound 4, half-maximal inhibitory concentration: 3800 nM
Compound 4: middle estimate off by 1.1-fold (0.04 log units), on the high side, within the range that was stated.
By their numbers in this assay, from the lowest: compounds 1 and 4 (each within the scatter of the next); then compounds 2 and 3 (each within the scatter of the next).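

In this assay, the exchange of fluoro for trifluoromethyl on an aromatic carbon, ortho to a large group, now has a measured pair of its own (a 2.3-fold lower number from compound 2 to compound 4 (0.37 log units; beyond the scatter)), and this modest step lies beyond the scatter, so the number at this position does respond to the change. The other new step (a 1.3-fold higher number from compound 1 to compound 4 (0.12 log units; within the scatter)) stays within the scatter, so with trifluoromethyl in place, methyl and hydrogen on the amine nitrogen in a ring are not told apart, just as the earlier step at that nitrogen, made with fluoro in place, stayed within the scatter. No measurement given here speaks to the reason for the step from fluoro to trifluoromethyl.

The compounds shown leave open whether another group on this aromatic carbon, such as chloro, methoxy or a nitrile, would give a number nearer that of fluoro or that of trifluoromethyl. They also leave open whether the step holds with (4-chlorophenyl)sulfonyl on the amine nitrogen, a group that appears here only together with fluoro.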